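The source may hold more compounds than are shown below. What is called first, only, known or untested is meant among the compounds shown, and "the series" means these compounds.

For the measured compounds named here, compound 1 `O=c1c2cccnc2sn1-c1ccc(Br)cc1` was measured in an assay for inhibition of histone acetyltransferase KAT2B (Homo sapiens), read by fluorescence (on this read-out lower numbers stand for stronger inhibition and higher numbers for weaker inhibition), and gave 4430 nM, the lowest of the two numbers known so far. Compound 2 `CCCCc1ccc(-n2sc3ncccc3c2=O)cc1` gave 15900 nM in this assay, and a 3.6-fold higher number from compound 1 to compound 2 (0.55 log units; beyond the scatter). Compound 3 `Cc1cnc2sn(-c3ccc(Br)cc3)c(=O)c2c1` has not yet been measured; it differs from compound 1 by methyl in place of hydrogen on an aromatic carbon. Going by the values given here, the single measured step concerns a substituent on the other aromatic ring of the shared core, so no measured step bears directly on this change, and there is no precedent for altering the fused ring. In the absence of such data, the expectation for compound 3 in this assay is a step of a 1.0-fold higher number from compound 1 to compound 3 (0.01 log units; within the scatter), that is, no change beyond the scatter. The estimate for compound 3 is therefore 4500 nM, with a range from 1800 nM to 12000 nM.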

Compound 3, half-maximal inhibitory concentration: 2990 nM
For compound 3 the middle estimate is 1.5-fold (0.18 log units) above the measured one; the measured number falls inside the stated range.
By their numbers in this assay, from the lowest: compounds 3 and 1 (each within the scatter of the next); then compound 2.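

For the compounds shown here, the step of a 1.5-fold lower number from compound 1 to compound 3 (0.17 log units; within the scatter) gives the first reading in this assay for a change on the fused ring, at a carbon two atoms from the ring nitrogen, and it lies within the scatter, so the numbers of these two compounds cannot be told apart. Going by these compounds alone, the only earlier step, a 3.6-fold higher number from compound 1 to compound 2 (0.55 log units; beyond the scatter), concerned the other aromatic ring and lay beyond the scatter; this position, by contrast, takes a methyl in place of hydrogen with no step beyond the scatter. No measurement at hand offers an explanation for this result.

Going by these compounds, whether a longer chain, an amine or a carboxylic acid at this position would also stay within the scatter of compound 1 remains open. On these data alone, it is also open whether the methyl would give a similar step on the butyl compound, compound 2.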